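Longer Alkyne Chain, Cytotoxicity Limits in HEL Cells

The compounds below may be only part of what the source reports. "The series", "measured", "known", "first", "only" and "open" are said of these compounds alone.

Compound 1, `CCCCCCCc1cc2cn([C@H]3C[C@H](O)[C@@H](CO)O3)c(=O)nc2o1`, gives > 50000 nM in a functional assay on HEL cells (Homo sapiens) for cytotoxicity; a lower number here means that less compound is tolerated, a higher number that more compound is tolerated; this value is a limit of the assay, not a number.
Compound 2, `C=CCCCc1cc2cn([C@H]3C[C@H](O)[C@@H](CO)O3)c(=O)nc2o1`, gives > 200000 nM in this assay; this too is a limit.
Compound 3, `C#CCCCCc1cc2cn([C@H]3C[C@H](O)[C@@H](CO)O3)c(=O)nc2o1`, gives > 200000 nM in this assay; again only a limit.

Going by the values given here, compound 2 therefore stands at a limit, and the two further values shown are limits as well: the limit of > 200000 nM in this assay, at which 2 of the 3 values shown sit, and the limit of > 50000 nM in this assay, at which 1 of the 3 values shown sits, describe the whole picture, with no compound giving a real number.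

Compound 4, `C#CCCCCCCc1cc2cn([C@H]3C[C@H](O)[C@@H](CO)O3)c(=O)nc2o1`, is the unmeasured compound. Its difference from compound 2 is pent-4-yn-1-yl in place of vinyl on a saturated chain carbon, three bonds along the chain from an aromatic carbon. The vinyl leaves and the pent-4-yn-1-yl enters, a longer chain ending in a triple bond.

The measured steps that bear on this change all lie between limits: a step that the two limits leave unreadable from compound 1 to compound 2, a step that the two limits leave unreadable from compound 2 to compound 3 and a step that the two limits leave unreadable from compound 1 to compound 3. None of them shows a readable size or direction, so the data give no reason to expect compound 4 to leave the range of the limits.

Compound 4 is therefore estimated at 200000 nM, with a range from 100000 nM to 400000 nM, most likely again reported only as a limit. The step of a number no higher from compound 2 to compound 4 (the limit leaves the size open) that this estimate means is expected to stay within the scatter.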

Compound 4, half-maximal cytotoxic concentration: > 200000 nM
Compound 4 gave a limit, no number; the forecaster's own chance of this, stated with the estimate: 85%; the middle value sits exactly at the limit.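

In this assay compound 4 gives > 200000 nM, which is a limit and not a number. Going by these compounds alone, compound 1, compound 2 and compound 3 also gave only limits, so no step from any of them to compound 4 can be read. The compounds shown leave open what concentration of any of them is cytotoxic, and whether the chain changes it.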